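The source may hold more compounds than are shown below. What is called first, only, known or untested is meant among the compounds shown, and "the series" means these compounds.

Working notes on the series. For the measured compounds named here, in a functional assay on DU-145 cells (Homo sapiens) for inhibition, read by trypan blue exclusion, with a stated time of 96 h (a lower number here means a stronger inhibitor of growth, a higher number a weaker inhibitor of growth), compound 1 `O=C(/C(=C\c1ccc(Cl)cc1Cl)S(=O)(=O)c1ccc(Br)cc1)c1ccc(Br)cc1` gives 10000 nM and compound 2 `O=C(/C(=C\c1ccc(F)cc1)S(=O)(=O)c1ccc(Br)cc1)c1ccc(Br)cc1` gives 4000 nM as the lowest number so far. Compound 3 `COc1cccc(OC)c1/C=C(\C(=O)c1ccc(Br)cc1)S(=O)(=O)c1ccc(Br)cc1` gives 10000 nM and sits level with compound 1, the two together holding the highest of the three numbers.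

Compound 4 `COc1ccc(/C=C(\C(=O)c2ccc(Br)cc2)S(=O)(=O)c2ccc(Br)cc2)c(OC)c1` differs from compound 3 by one exchange (2,4-dimethoxyphenyl in place of 2,6-dimethoxyphenyl on a double-bonded chain carbon bound to a double-bonded chain carbon), and the group stays on a double-bonded chain carbon bound to a double-bonded chain carbon.

Going by the values given here, no measured step covers this exact exchange, but three steps at the same place bear on it. Two are modest, a 2.5-fold lower number from compound 1 to compound 2 (0.40 log units; beyond the scatter) and a 2.5-fold higher number from compound 2 to compound 3 (0.40 log units; beyond the scatter), while no change at the digits printed from compound 1 to compound 3 (within the scatter) stays within the scatter. The name 2,4-dimethoxyphenyl shares its numbering with the 2,4-dichlorophenyl of compound 1 at 10000 nM, which favours the high level, while compound 2 at 4000 nM marks the lower edge of the numbers seen so far. No change beyond the scatter is therefore expected, with only a slight lean towards a lower number.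

The expected step is a 1.4-fold lower number from compound 3 to compound 4 (0.15 log units; within the scatter) and would lie within the scatter. For compound 4 the estimate is 7000 nM, with an expected range of 3000 nM to 14000 nM.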

Compound 4, concentration for 50% growth inhibition: 8000 nM
Estimate against measurement, compound 4: 1.1-fold (0.06 log units) below; low and high end bracket the measured number.
By their numbers in this assay, from the lowest: compounds 2, 4, 1 and 3 (each within the scatter of the next, the first and the last beyond it).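

In this assay, the exchange of 2,6-dimethoxyphenyl for 2,4-dimethoxyphenyl on a double-bonded chain carbon bound to a double-bonded chain carbon gives a 1.3-fold lower number from compound 3 to compound 4 (0.10 log units; within the scatter), so this first pair with the same atoms joined differently does not separate the two dimethoxy patterns. Compound 4 also cannot be told apart from either of the two earlier substituent types, with a 1.3-fold lower number from compound 1 to compound 4 (0.10 log units; within the scatter) against the 2,4-dichlorophenyl compound and a 2.0-fold higher number from compound 2 to compound 4 (0.30 log units; within the scatter) against the 4-fluorophenyl compound, although compound 1 and compound 2 themselves differ beyond the scatter, which leaves the series at this position as a shallow spread rather than two distinct levels. Nothing on hand explains these numbers or the small size of the spread.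

As far as these compounds go, whether a single methoxy group, an amine or a carboxylic acid on the phenyl ring at this place would move the number beyond the scatter of compound 2 stays open. Also open, from the compounds shown here alone, is whether the flat picture across compounds 1 to 4 holds in other cell lines or with changes elsewhere on the shared core.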